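Removing the Last Hydroxy from a Dienamide Series

This account rests on a few compounds, and the source may have more. Where it says the series, first, only, none or still open, it means among the compounds named here.

Measured compounds:
compound 1 `COc1cc(/C=C/C=C/C(=O)N2CCCCC2)cc(OC)c1O` — 32.7%
compound 2 `O=C(/C=C/C=C/c1cc(O)c(O)c(O)c1)N1CCCCC1` — 82.5%
compound 3 `O=C(/C=C/C=C/c1ccc(O)c(O)c1)N1CCCCC1` — 82.8%

In an assay for inhibition of Polyunsaturated fatty acid 5-lipoxygenase (Homo sapiens), read by spectrophotometry, tested at 20 uM (on this read-out higher numbers stand for more inhibition at the one concentration tested (going by the name of the read-out) and lower numbers for less inhibition), compound 1 gives 32.7%, compound 2 gives 82.5% and compound 3 gives 82.8%. The difference between the core of compound 1 and that of compound 2 is not broken down here. Compounds 2 and 3 differ by one change, (hydrogen in place of hydroxy on an aromatic carbon), and the step is a number 0.3 percentage points higher from compound 2 to compound 3 (within the scatter). Compound 4 `COc1cc(/C=C/C=C/C(=O)N2CCCCC2)cc(OC)c1` is not yet measured; it arises from compound 1 by the same kind of change, (hydrogen in place of hydroxy on an aromatic carbon), but here the place is ortho to two methoxy groups and para to a large group, while in compound 3 it was ortho to a hydroxy group, meta to a hydroxy group and meta to a large group. Compound 4 then carries no hydroxy at all, and compound 1 is already the lowest of the three. Since the earlier step stayed within the scatter, compound 4 is expected at 18%, a step of a number 14.7 percentage points lower from compound 1 to compound 4 (beyond the scatter), with the wide range 0% to 38% reflecting that the surroundings differ from the measured case.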

Compound 4, a percentage reported as inhibition, at one concentration (the size of the read-out at that concentration, not a potency): 64.9%
Compound 4: the middle estimate sits 46.9 percentage points below what was measured; measured number above the stated range.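

In this assay, putting hydrogen in place of hydroxy on an aromatic carbon gives a number 32.2 percentage points higher from compound 1 to compound 4 (beyond the scatter). The size of this change therefore does not carry over unchanged from one core to another in this series, as the two steps show: the same change on two cores in this assay, a number 0.3 percentage points higher (within the scatter) from compound 2 to compound 3 and a number 32.2 percentage points higher (beyond the scatter) from compound 1 to compound 4, 31.9 percentage points apart, beyond the scatter of two such steps

This does not show why the steps differ, since the two places have different surroundings and the cores differ as well, and two steps give no rule for other cores in the series.

The compounds shown leave open whether an amine or a chlorine atom in place of the hydroxy would give a value close to that of compound 4. Also open, on these data alone, is whether a longer chain in place of either methoxy group would change the size of the step.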